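Series notes: substituent on the pyrrole-type ring carbon of the core

The source may hold more compounds than are shown below. What is called first, only, known or untested is meant among the compounds shown, and "the series" means these compounds.

Measured compounds in an assay on isolated protein for binding affinity to Apoptosis regulator Bcl-2 (Homo sapiens), read by fluorescence polarization, with a stated time of 2 h; a lower number here means a stronger inhibitor, a higher number a weaker inhibitor:
compound 1 `Cc1c(C(=O)N[C@H]2C[C@@](C)(O)C2)c(-c2cccc(N3CCN(c4ccc(NS(=O)(=O)c5ccc(N[C@H](CCN(C)C)CSc6ccccc6)c([N+](=O)[O-])c5)cc4)CC3)c2)c(-c2ccc(Cl)cc2)n1C` gives 7.5 nM;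
compound 2 `Cc1c(C(=O)NS(C)(=O)=O)c(-c2cccc(N3CCN(c4ccc(NS(=O)(=O)c5ccc(N[C@H](CCN(C)C)CSc6ccccc6)c([N+](=O)[O-])c5)cc4)CC3)c2)c(-c2ccc(Cl)cc2)n1C` gives 0.9 nM;
compound 3 `Cc1c(C(F)(F)F)c(-c2cccc(N3CCN(c4ccc(NS(=O)(=O)c5ccc(N[C@H](CCN(C)C)CSc6ccccc6)c([N+](=O)[O-])c5)cc4)CC3)c2)c(-c2ccc(Cl)cc2)n1C` gives 271 nM.

Compound 3 carries the highest number of the three: the steps of a 36-fold higher number from compound 1 to compound 3 (1.56 log units; beyond the scatter) and a 300-fold higher number from compound 2 to compound 3 (2.48 log units; beyond the scatter) both run to it, so the group on this aromatic carbon matters strongly. The next compound, compound 4 `Cc1c(C#N)c(-c2cccc(N3CCN(c4ccc(NS(=O)(=O)c5ccc(N[C@H](CCN(C)C)CSc6ccccc6)c([N+](=O)[O-])c5)cc4)CC3)c2)c(-c2ccc(Cl)cc2)n1C`, differs from compound 3 by cyano in place of trifluoromethyl on an aromatic carbon. Within the data shown here, no measured step shows a cyano group anywhere; the two steps that do bear on this position only show that departing from trifluoromethyl toward an acceptor-bearing group lowered the number, once by a modest margin and once by a large one. A modest downward step is therefore expected, a 2.3-fold lower number from compound 3 to compound 4 (0.35 log units; beyond the scatter), well short of what compound 2 shows. Compound 4 is estimated at 120 nM, with a range of 40 nM to 400 nM.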

Compound 4, half-maximal inhibitory concentration: 17 nM
Compound 4: middle estimate off by 7.1-fold (0.85 log units), on the high side, outside the stated range (below it).
By their numbers in this assay, from the lowest: compound 2; then compound 1; then compound 4; then compound 3.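

In this assay, cyano improves markedly on trifluoromethyl, a 16-fold lower number from compound 3 to compound 4 (1.20 log units; beyond the scatter), even though cyano has fewer heavy atoms, so the number does not follow heavy-atom count across compound 3 and compound 4. Cyano nearly matches the far larger amide group of compound 1, a 2.3-fold higher number from compound 1 to compound 4 (0.36 log units; beyond the scatter), but still trails (methylsulfonyl)carbamoyl, a 19-fold higher number from compound 2 to compound 4 (1.28 log units; beyond the scatter). Nothing available accounts for the gain seen with cyano.

Open, from the compounds shown here alone, is whether a carboxylic acid or a primary amide on this aromatic carbon would stand nearer compound 2 or compound 4.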